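A few compounds are considered here, and "the series" means these few. Any claim that something is new, unique, unknown or untested is made for them only; others in the source may bear on it.

Compound 2 `Oc1ccc(-c2cc(-c3ccco3)cc(-c3cccc(O)c3)n2)cc1` gives 840 nM in a functional assay on HCT-15 cells (Homo sapiens) for cytotoxicity, read by CCK-8 assay (on this read-out lower numbers stand for stronger inhibition and higher numbers for weaker inhibition), and stands lowest of the two numbers shown there. Compound 3 `Oc1ccc(-c2cc(-c3ccco3)cc(-c3ccc(O)cc3)n2)cc1` gives 14000 nM in this assay, which is a 17-fold higher number from compound 2 to compound 3 (1.22 log units; beyond the scatter). Compound 1 `Oc1cccc(-c2cc(-c3ccco3)cc(-c3ccccc3O)n2)c1` reaches only (the limit of > 50000 nM in this assay, at which 1 of the 3 values shown sits); its entry of > 50000 nM is a limit of the assay and not a number. Compound 4 `Oc1ccc(-c2cc(-c3cccnc3)cc(-c3cccc(O)c3)n2)cc1` differs from compound 2 by pyridin-3-yl in place of furan-2-yl on an aromatic carbon. Within the data shown here, the measured steps, an at least 59-fold lower number from compound 1 to compound 2 (1.77 log units; beyond the scatter) and a 17-fold higher number from compound 2 to compound 3 (1.22 log units; beyond the scatter), both move a hydroxyl between positions on the phenyl rings; neither touches the five-membered aromatic ring, so no measured step bears directly on this change. Lacking such evidence, the expected step is modest with a wide range: a 1.8-fold higher number from compound 2 to compound 4 (0.25 log units; within the scatter). Compound 4 is therefore estimated at 1500 nM, between 300 nM and 8000 nM.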

Compound 4, half-maximal inhibitory concentration: > 50000 nM
Compound 4 was reported as a limit (the forecaster's own chance of this, stated with the estimate: 5%); middle value at least 33-fold (1.52 log units) away from the limit.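

In this assay, among these compounds, the position opposite the ring nitrogen, untouched by the earlier steps, proves sensitive in its own right: pyridin-3-yl in place of furan-2-yl brings an at least 59-fold higher number from compound 2 to compound 4 (1.77 log units; beyond the scatter) on this single change. The entry of compound 4 is a limit and not a number, and it joins compound 1 at that limit: the limit of > 50000 nM in this assay, at which 2 of the 4 values shown sit.

Ring size and hetero atom change together in this step, so the compounds shown do not separate them. From the compounds shown here alone, a plain phenyl ring or a thiophene ring, with sulfur as its hetero atom, at this position remains open.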